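Toward a Free Amine on the Side Chain of Compound 2

This account rests on a few compounds, and the source may have more. Where it says the series, first, only, none or still open, it means among the compounds named here.

In a functional assay on the whole organism (Tail, strain ICR) with Mus musculus as the target, in the tail flick test, with a stated time of 30 min, at a dose of 25 umol/kg by the oral route (a lower number here means a weaker effect, a higher number a stronger effect of the compound at the dose given), two compounds have been measured so far. Compound 1, `N=C(N)NCCC[C@H](NC(=O)CN(c1nc(Cl)nc2[nH]cnc12)C1CC1)C(=O)OCc1ccccc1`, gives 23.2%. Compound 2, `O=C(CN(c1nc(Cl)nc2[nH]cnc12)C1CC1)N[C@@H](CCC(=O)OCc1ccccc1)C(=O)OCc1ccccc1`, gives 52.8%. Compound 2 stands highest of the two numbers; its nearest neighbour is compound 1, and the step of a number 29.6 percentage points higher from compound 1 to compound 2 (beyond the scatter) lies beyond the scatter. Compound 3, `NCCCC[C@H](NC(=O)CN(c1nc(Cl)nc2[nH]cnc12)C1CC1)C(=O)OCc1ccccc1`, has not yet been measured in this assay. It differs from compound 2 in one place: 2-aminoethyl in place of benzyloxycarbonyl on a saturated chain carbon, three bonds along the chain from an amide-type nitrogen and a carbonyl carbon. Among the measured compounds shown here, the only measured step that bears on this change is a number 29.6 percentage points higher from compound 1 to compound 2 (beyond the scatter), in which a group of 10 heavy atoms with one six-membered aromatic ring of carbon only took the place of a group with no ring; compound 3 moves in the opposite sense, with 2-aminoethyl in place of benzyloxycarbonyl. For the measured compounds named here, a drop of roughly that size is therefore anticipated, though the entering group is not the one found in compound 1, so the expectation is loose. For compound 3 the estimated value in this assay is 28%, with a range from 12% to 45%. The expected step is a number 24.8 percentage points lower from compound 2 to compound 3 (beyond the scatter).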

Compound 3, a percentage reported as activity, at one dose (the size of the read-out at that dose, not a potency): 26.1%
Compound 3: middle estimate off by 1.9 percentage points, on the high side; low and high end bracket the measured number.
By their numbers in this assay, from the lowest: compounds 1 and 3 (each within the scatter of the next); then compound 2.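

In this assay the exchange of benzyloxycarbonyl for 2-aminoethyl can now be read directly, as a number 26.7 percentage points lower from compound 2 to compound 3 (beyond the scatter) and beyond the scatter, so the loss seen at this saturated chain carbon does not depend on the group that entered in compound 1. The two side chains that end in nitrogen groups cannot be told apart here: the exchange four bonds along the chain from the amide-type nitrogen and the carbonyl carbon reads as a number 2.9 percentage points higher from compound 1 to compound 3 (within the scatter) and stays within the scatter. Across these few compounds, compound 2, the only one carrying a second benzyloxycarbonyl group, stands apart from both others, and none of the three goes against that reading. Nothing shown here gives a reason for this difference.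

Open still is whether the higher read-out needs the whole benzyloxycarbonyl group, since a carboxylic acid or a simple methyl ester at this place would separate the aromatic ring from the carbonyl part. Going by these compounds, it is equally open whether a longer chain carrying the amine would stay level with compound 3 or move away from it.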